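Working notes on the step to compound 3

The source may hold more compounds than are shown below. What is called first, only, known or untested is meant among the compounds shown, and "the series" means these compounds.

- compound 1 `c1ccc2c(c1)CN[C@@H](CN(CCCN1CCNCC1)[C@H]1CCCc3cccnc31)C2` gives 100%
- compound 2 `CCN1CCN(CCCN(C[C@H]2Cc3ccccc3CN2)[C@H]2CCCc3cccnc32)CC1` gives 59%

In an ADME assay on microsomes from liver (Homo sapiens) for metabolic stability, read by LC-MS, with a stated time of 10 min, tested at 0.5 uM (a lower number here means that less of the compound is left, a higher number that more of the compound is left), compound 1 stands highest of the two measured, at 100% with compound 2 well under it. Among the measured compounds shown here, compound 3 `c1cnc2c(c1)CN[C@H](CN(CCCN1CCNCC1)[C@H]1CCCc3cccnc31)C2` is unmeasured, and its change from compound 1 is a group of 10 heavy atoms (8 carbon, 2 nitrogen; one six-membered non-aromatic ring with 1 hetero atom, one six-membered aromatic ring with 1 hetero atom) in place of a group of 10 heavy atoms (9 carbon, 1 nitrogen; one six-membered non-aromatic ring with 1 hetero atom, one six-membered aromatic ring of carbon only), on a saturated chain carbon bound to an amine nitrogen with no measured step covering it. For the measured compounds named here, the one measured step of a number 41 percentage points lower from compound 1 to compound 2 (beyond the scatter) is large but concerns ethyl in place of hydrogen on an amine nitrogen in a ring, a different place, so it offers little guidance here. Expected is a modest drop, the estimated step being a number 8 percentage points lower from compound 1 to compound 3 (within the scatter) and not clearly beyond the scatter. The estimate for compound 3 is 92% with 75% to 100% as the expected range.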

Compound 3, percent of the compound remaining: 100%
Compound 3: the middle estimate sits 8 percentage points below what was measured; measured number inside the range.
By their numbers in this assay, from the lowest: compound 2; then compounds 1 and 3 (each within the scatter of the next).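

In this assay, replacing 1,2,3,4-tetrahydroisoquinolin-3-yl, on a saturated chain carbon bound to an amine nitrogen, with the group carrying a hetero atom in its six-membered aromatic ring gives no change at the digits printed from compound 1 to compound 3 (within the scatter). Among the compounds shown here, this is the first reading at this position, and the ring nitrogen leaves the compound remaining unchanged within the scatter. Nothing available bears on why this is so.

From the compounds shown here alone, whether the same exchange holds alongside the ethyl of compound 2 remains open. So does the outcome of a methoxy group or a chlorine on that aromatic ring.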